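A few compounds are considered here, and "the series" means these few. Any claim that something is new, unique, unknown or untested is made for them only; others in the source may bear on it.

In an ADME assay on Raji cells (Homo sapiens) for cytotoxicity, read by luminescence, with a stated time of 72 h (on this read-out higher numbers stand for an effect only at larger amounts of compound and lower numbers for an effect already at smaller amounts), three compounds with a shared core have been tested so far. Compound 1 (`CCOC(=O)c1c(-c2cccc(Oc3ccccc3)c2)[nH]c2cc(OC)ccc2c1=O`) gives > 21500 nM as a limit of the assay, not a number. Compound 2 (`CCOC(=O)c1c(-c2cccc(-c3ccccc3)c2)[nH]c2cc(OC(C)C)ccc2c1=O`) gives > 21500 nM as a limit too. Compound 3 (`CCOC(=O)c1c(-c2cccc(-c3ccccc3)c2)[nH]c2cc(O)ccc2c1=O`) gives > 21500 nM as a limit as well, so it offers no true number as a starting point. So far the data hold the limit of > 21500 nM in this assay, at which 3 of the 3 values shown sit, and no true number at all.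

Compound 4 (`CCOC(=O)c1c(-c2cccc(Oc3ccccc3)c2)[nH]c2cc(O)ccc2c1=O`) differs from compound 3 in one place, with phenoxy in place of phenyl (phenoxy in place of phenyl on an aromatic carbon). Among the measured compounds shown here, the one measured step (a step that the two limits leave unreadable from compound 2 to compound 3) is a different change, hydrogen in place of isopropyl on an oxygen on an aromatic ring, and it has no readable size. The closest guide is therefore a single compound. Since compound 1 with the phenoxy group gives > 21500 nM as a limit too, no step beyond the usual scatter is expected in this assay in either direction. The expected step (a step that the limit leaves unreadable from compound 3 to compound 4) is only an estimate. For compound 4 the estimate is 27000 nM with an expected range from 15000 nM to 50000 nM and a high chance that the outcome is again only a limit.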

Compound 4, half-maximal effective concentration: > 21500 nM
Compound 4: a limit, no number; the forecaster's own chance of this, stated with the estimate: 85%; the middle value lies beyond the limit too.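

In this assay compound 4 gives > 21500 nM, a limit and not a number. Its steps from compound 1 and from compound 3 therefore cannot be read, and every result so far is the same limit: the limit of > 21500 nM in this assay, at which 4 of the 4 values shown sit. The compounds shown leave open at what amount any of them would act on these cells, and whether phenoxy in place of phenyl, or a change of the group on the oxygen, makes any difference.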